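A few compounds are considered here, and "the series" means these few. Any claim that something is new, unique, unknown or untested is made for them only; others in the source may bear on it.

Three compounds share the same core and differ only in the group attached at one saturated ring carbon of it. Compound 1 `Cc1cc(O)c(C2=NN(c3ccc(S(N)(=O)=O)cc3)C(c3ccccc3O)C2)cc1Cl` carries a 2-hydroxyphenyl group there, and in a functional assay on M14 cells (Homo sapiens) for antiproliferative activity, with a stated time of 48 h (a lower number here means a stronger inhibitor of growth, a higher number a weaker inhibitor of growth), compound 1 gives 1760 nM. Compound 2 `Cc1cc(O)c(C2=NN(c3ccc(S(N)(=O)=O)cc3)C(c3ccccc3Cl)C2)cc1Cl` carries a 2-chlorophenyl group instead, and in this assay compound 2 gives 1850 nM; the step of a 1.1-fold higher number from compound 1 to compound 2 (0.02 log units; within the scatter) lies within the scatter. Compound 3 `Cc1cc(O)c(C2=NN(c3ccc(S(N)(=O)=O)cc3)C(/C=C/c3ccccc3)C2)cc1Cl` carries a 2-phenylethenyl group, and in this assay compound 3 gives 6160 nM, the highest of the three numbers, separated from both others by more than the scatter. The steps of a 3.5-fold higher number from compound 1 to compound 3 (0.54 log units; beyond the scatter) and a 3.3-fold higher number from compound 2 to compound 3 (0.52 log units; beyond the scatter) show that exchanging an aryl group at this carbon for the 2-phenylethenyl group raised the number modestly in both cases.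

Compound 4 `COc1ccc(C2CC(c3cc(Cl)c(C)cc3O)=NN2c2ccc(S(N)(=O)=O)cc2)cc1OC` has not yet been measured. It differs from compound 3 in that (3,4-dimethoxyphenyl in place of 2-phenylethenyl on a saturated ring carbon). Because a 3.5-fold higher number from compound 1 to compound 3 (0.54 log units; beyond the scatter) and a 3.3-fold higher number from compound 2 to compound 3 (0.52 log units; beyond the scatter) both went upward when an aryl group gave way to 2-phenylethenyl, the reverse exchange for an aryl group is expected to lower the number in this assay by a comparable modest amount, although the 3,4-dimethoxyphenyl group is not the same aryl group as in compound 1 or compound 2, which widens the uncertainty. The expected step is a 3.1-fold lower number from compound 3 to compound 4 (0.49 log units; beyond the scatter). In this assay compound 4 is therefore estimated at 2000 nM, with a range from 800 nM to 5000 nM.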

Compound 4, concentration for 50% growth inhibition: 2610 nM
Compound 4: middle estimate off by 1.3-fold (0.12 log units), on the low side; the measured number falls inside the stated range.
By their numbers in this assay, from the lowest: compounds 1, 2 and 4 (each within the scatter of the next); then compound 3.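

Compound 4 brings a third aryl group to this saturated ring carbon, and the step of a 2.4-fold lower number from compound 3 to compound 4 (0.37 log units; beyond the scatter) in this assay runs opposite to the two earlier exchanges that introduced 2-phenylethenyl, so that group now stands apart from three different aryl groups rather than two. The steps of a 1.4-fold higher number from compound 2 to compound 4 (0.15 log units; within the scatter) and a 1.5-fold higher number from compound 1 to compound 4 (0.17 log units; within the scatter) both lie within the scatter, which means that 3,4-dimethoxyphenyl, with its two hydrogen-bond acceptors, cannot be told apart here from 2-hydroxyphenyl or 2-chlorophenyl. Across these four compounds, with none going against it, the only difference beyond the scatter at this carbon is that between 2-phenylethenyl and an aryl group, while the choice among the three aryl groups shown leaves the number within the scatter.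

No measurement is at hand that bears on the reason for this difference. The compounds shown leave open whether a 2-phenylethyl chain, with the double bond gone, would track with 2-phenylethenyl or with the aryl groups, and whether a methyl group or a phenyl group carrying an amine or a carboxylic acid would fit the same picture.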